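Cytotoxicity of a shared-core amide series, with a gap

This account rests on a few compounds, and the source may have more. Where it says the series, first, only, none or still open, it means among the compounds named here.

The compounds here share one core and differ only in the group carried on the amide-type nitrogen. Compound 1 is `CCC(C)(C)NC(=O)COC(=O)c1ccc([N+](=O)[O-])o1`, compound 2 is `O=C(COC(=O)c1ccc([N+](=O)[O-])o1)NCC1CCCO1` and compound 3 is `CC(C)(C)N(CCCc1ccccc1)C(=O)COC(=O)c1ccc([N+](=O)[O-])o1`. In an ADME assay on HEK-293T cells (Homo sapiens) for cytotoxicity, read by MTT assay, with a stated time of 3 days (on this read-out higher numbers stand for lower toxicity in this test and lower numbers for higher toxicity in this test), compound 1 gives > 100000 nM, which is a limit of the assay and not a number. In this assay compound 2 gives > 100000 nM, again a limit. Because both values sit at the limit of > 100000 nM in this assay, at which 2 of the 3 values shown sit, the step that the two limits leave unreadable from compound 1 to compound 2 cannot be read. In this assay compound 3 is recorded as "not active" (no number reported), with no number at all. The two other values shown in this series are themselves limits, and nothing in the numbers sets compound 3 apart from compound 1 or compound 2.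

Compound 4 is `CC(C)(C)N(Cc1cccc(C(F)(F)F)c1)C(=O)COC(=O)c1ccc([N+](=O)[O-])o1`. It differs from compound 3 by 3-(trifluoromethyl)phenyl in place of phenethyl on a saturated chain carbon bound to an amide-type nitrogen. No measured step bears directly on this exchange: the only step shown, from compound 1 to compound 2, is unreadable, and every measured value is a limit or carries no number. On that footing no step beyond the usual scatter can be expected in either direction. Compound 4 is therefore estimated to give about 150000 nM in this assay, within a range from 60000 nM to 400000 nM, most likely again reported only as a limit.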

Compound 4, half-maximal cytotoxic concentration: 68000 nM
Compound 4: the middle estimate sits 2.2-fold (0.34 log units) above what was measured; the measured number falls inside the stated range.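

Compound 3 carries no number in this assay, while compound 4 gives 68000 nM, and no new step can be read between compound 3 and compound 4. The compounds shown leave open how far the group on the amide-type nitrogen can shift cytotoxicity, since the remaining numerical entries are limits: the limit of > 100000 nM in this assay, at which 2 of the 4 values shown sit.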